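Moving a Hydroxyl Group Across a Phenyl Ring

A few compounds are considered here, and "the series" means these few. Any claim that something is new, unique, unknown or untested is made for them only; others in the source may bear on it.

Measured compounds:
compound 1, `O=C(/C=C/c1ccccc1O)CC(=O)/C=C/c1cccc(O)c1O`, gives 34000 nM in an ADME assay on PC-12 cells (Rattus norvegicus) for cytotoxicity, read by WST assay, with a stated time of 24 h; on this read-out higher numbers stand for lower toxicity in this test and lower numbers for higher toxicity in this test
compound 2, `O=C(/C=C/c1cccc(O)c1)CC(=O)/C=C/c1cccc(O)c1O`, gives 38000 nM in this assay
compound 3, `O=C(/C=C/c1ccc(O)c(O)c1)/C=C/c1ccccc1O`, gives 34000 nM in this assay

Compound 1 and compound 2 differ in a single place: 3-hydroxyphenyl in place of 2-hydroxyphenyl on a double-bonded chain carbon bound to a double-bonded chain carbon. In this assay this gave a 1.1-fold higher number from compound 1 to compound 2 (0.05 log units; within the scatter), so the two compounds behave alike on this read-out. Compound 3 stands level with compound 1 at the digits printed, and compound 2 sits only a little away from both, all within the usual spread of repeated measurements. Compound 3 differs from compound 1 in more than one place; the difference between these two cores is not broken down here.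

Compound 4, `O=C(/C=C/c1cccc(O)c1)/C=C/c1ccc(O)c(O)c1`, has not yet been measured. It differs from compound 3 by 3-hydroxyphenyl in place of 2-hydroxyphenyl on a double-bonded chain carbon bound to a double-bonded chain carbon. The surroundings of the change are described in the same words for both pairs, so this is the same change that was made from compound 1 to compound 2.

The step is expected to be a 1.1-fold higher number from compound 3 to compound 4 (0.02 log units; within the scatter). This expectation rests on the fact that the identical change earlier gave a 1.1-fold higher number from compound 1 to compound 2 (0.05 log units; within the scatter), a shift that stayed within the scatter. Compound 4 is therefore estimated at 36000 nM, most likely between 18000 nM and 72000 nM.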

Compound 4, half-maximal cytotoxic concentration: > 100000 nM
Compound 4 ended at the assay's limit (the forecaster's own chance of this, stated with the estimate: 10%); at least 2.7-fold (0.44 log units) between middle value and limit.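

In this assay compound 4 gives > 100000 nM, which is a limit of the assay and not an exact number. As far as these compounds go, on the core of compound 3, putting 3-hydroxyphenyl in place of 2-hydroxyphenyl produced an at least 2.9-fold higher number from compound 3 to compound 4 (0.46 log units; beyond the scatter), so on this core the change goes with lower toxicity in this test, and the true size of the step remains unknown. Set beside the earlier step, this result neither proves that the change carries over from one core to the other nor proves that it behaves differently on each, and a single pair on each core cannot settle the matter: the same change on two cores in this assay, a 1.1-fold higher number (0.05 log units; within the scatter) from compound 1 to compound 2 and an at least 2.9-fold higher number (0.46 log units; beyond the scatter) from compound 3 to compound 4; the limit leaves it open whether they differ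

The compounds shown leave open how far compound 4 really lies from compound 3, and a measurement that ends at a limit cannot close that gap: the limit of > 100000 nM in this assay, at which 1 of the 4 values shown sits. They also leave open whether the same swap would follow either step on other cores in this series, and what would happen if a methoxy group or an amine stood in place of the hydroxyl group on the moved ring.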